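Swapping Bromo for Methyl on a Weak Antiproliferative

The compounds below may be only part of what the source reports. "The series", "measured", "known", "first", "only" and "open" are said of these compounds alone.

In a functional assay on MCF7 cells (Homo sapiens) for antiproliferative activity, read by MTT assay, with a stated time of 48 h (a higher number here means a weaker inhibitor, a lower number a stronger inhibitor), compound 1 (`O=C(/C=C/c1ccccc1Br)c1nc2ccccc2[nH]1`) gives 50900 nM. Compound 2 (`O=C(/C=C/c1cccc(Cl)c1)c1nc2ccccc2o1`) gives > 100000 nM, which is the limit of > 100000 nM in this assay, at which 1 of the 2 values shown sits, and not a number. Compound 1 therefore holds the only actual number shown, the other value being a limit. Compound 3 (`Cc1ccccc1/C=C/C(=O)c1nc2ccccc2[nH]1`) differs from compound 1 by methyl in place of bromo on an aromatic carbon. Going by the values given here, no measured pair shows this change, so any shift is expected to stay close to the scatter, leaning if anything toward weaker inhibition. Compound 3 is expected to give 65000 nM in this assay, between 25000 nM and 160000 nM, an estimated step of a 1.3-fold higher number from compound 1 to compound 3 (0.11 log units; within the scatter).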

Compound 3, half-maximal inhibitory concentration: 62500 nM
Estimate against measurement, compound 3: 1.0-fold (0.02 log units) above, within the range that was stated.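

In this assay, methyl in place of bromo on an aromatic carbon, ortho to a large group, gives a 1.2-fold higher number from compound 1 to compound 3 (0.09 log units; within the scatter). Going by these compounds alone, this is the first step that can be read at this position, and it shows that these two groups, each of one heavy atom, cannot be told apart here. Nothing at hand bears on why the two groups read alike.

From the compounds shown here alone, whether an amine, a carboxylic acid or a longer chain at this place would move the number beyond the scatter stays open. The same holds for other positions on the shared core, since this single pair speaks for this position only.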